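Series notes: solubility at acidic pH, benzyl for pentan-3-yl

The compounds below may be only part of what the source reports. "The series", "measured", "known", "first", "only" and "open" are said of these compounds alone.

Measured so far:
compound 1 `CCC(CC)C(/C=C1\OC(=O)NC1=O)c1ccc(-c2ccc3cccc(F)c3c2)[nH]c1=O`: 3680 nM
compound 2 `CC(C)/C(=C1/SC(=O)NC1=O)c1ccc(-c2ccc3cccc(F)c3c2)[nH]c1=O`: 9200 nM

In a physicochemical assay for solubility, measured as kinetic solubility, at pH 2 (on this read-out lower numbers stand for lower solubility and higher numbers for higher solubility), compound 1 gives 3680 nM, the lower of the two numbers measured. Compound 2 gives 9200 nM, a higher number beyond the scatter; these two differ in more than one place, so only their values are compared here.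

Compound 3 `O=C1NC(=O)/C(=C/C(Cc2ccccc2)c2ccc(-c3ccc4cccc(F)c4c3)[nH]c2=O)O1` differs from compound 1 in one place: benzyl in place of pentan-3-yl on a saturated chain carbon bound to an aromatic carbon and a double-bonded chain carbon. Going by the values given here, with no step of this kind measured, the expectation is a step from compound 1 to compound 3 of about a 1.2-fold lower number from compound 1 to compound 3 (0.09 log units; within the scatter), not clearly beyond the scatter. For compound 3 the estimated value in this assay is 3000 nM, within a range of 1000 nM to 9000 nM.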

Compound 3, solubility: 900 nM
Beside the measured number, compound 3's estimate is 3.3-fold (0.52 log units) above it; the whole stated range lies above it.
By their numbers in this assay, from the lowest: compound 3; then compound 1; then compound 2.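

In this assay, the group on the saturated chain carbon bound to an aromatic carbon and a double-bonded chain carbon makes a measurable difference. Benzyl in place of pentan-3-yl gives a 4.1-fold lower number from compound 1 to compound 3 (0.61 log units; beyond the scatter), the first one-place step in this series, and it rests on this single pair. Nothing at hand accounts for the size of this step.

Going by these compounds, whether the step follows the aromatic ring of benzyl or its carbon count stays open. Also open, on these data alone, is how an amine or a carboxylic acid at this place would read in this assay.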